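The source may hold more compounds than are shown below. What is called first, only, known or untested is meant among the compounds shown, and "the series" means these compounds.

In a functional assay on CCRF-CEM cells (Homo sapiens), read by MTT assay, with a stated time of 3 days (a lower number here means a stronger inhibitor, a higher number a weaker inhibitor), compound 1 `CN(C)c1ncnc2[nH]cc(Sc3cccs3)c12` gives 14600 nM and compound 2 `CNc1ncnc2[nH]cc(Sc3cccs3)c12` gives 14700 nM, so the two lie within the scatter of each other. Compound 3 `Nc1ncnc2[nH]cc(Sc3cccs3)c12` differs from compound 2 by hydrogen in place of methyl on a nitrogen on an aromatic ring. Among the measured compounds shown here, the one measured step of the same kind, a 1.0-fold higher number from compound 1 to compound 2 (0.00 log units; within the scatter), stayed within the scatter, so no step beyond the scatter is expected in this assay. The expected change is a 1.1-fold lower number from compound 2 to compound 3 (0.05 log units; within the scatter). For compound 3 the estimated value is 13000 nM, with an expected range of 6000 nM to 30000 nM.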

Compound 3, half-maximal inhibitory concentration: 16700 nM
Compound 3: middle estimate off by 1.3-fold (0.11 log units), on the low side, and the stated range covers the measured number.
By their numbers in this assay, from the lowest: compounds 1, 2 and 3 (each within the scatter of the next).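

In this assay, hydrogen in place of the remaining methyl on this nitrogen gives no step beyond the scatter (a 1.1-fold higher number from compound 2 to compound 3 (0.06 log units; within the scatter)), and neither does amino in place of dimethylamino on the aromatic carbon (a 1.1-fold higher number from compound 1 to compound 3 (0.06 log units; within the scatter)). The earlier pair covered only the first methyl; now amino, methylamino and dimethylamino all lie within the scatter of one another at this position. No measured evidence explains this. Going by these compounds, whether a longer chain such as propyl on this nitrogen, or a cyclic amine such as morpholine at this place, would shift the number remains open.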